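A few compounds are considered here, and "the series" means these few. Any claim that something is new, unique, unknown or untested is made for them only; others in the source may bear on it.

In a functional assay on ECa-109 cells (Homo sapiens) for antiproliferative activity, read by MTT assay, with a stated time of 72 h (on this read-out lower numbers stand for stronger inhibition and higher numbers for weaker inhibition), compound 1 (`CCCSc1nc(N/N=C/c2ccc(C)cc2)c2nnn(Cc3ccccc3)c2n1`) gives > 64000 nM. That value is a limit of the assay and not a number. Compound 1 therefore stands at the limit of > 64000 nM in this assay, at which 1 of the 2 values shown sits. Compound 2 (`C#CCSc1nc(N/N=C/c2c(O)ccc3ccccc23)c2nnn(Cc3ccccc3)c2n1`) gives a true number in this assay, with compound 2 reading 6520 nM. Compound 2 differs from compound 1 in more than one place, so their two values do not isolate the effect of any single change.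

Compound 3 (`CCCSc1nc(N/N=C/c2cccs2)c2nnn(Cc3ccccc3)c2n1`) changes compound 1 in one place: thiophen-2-yl in place of 4-methylphenyl on a carbon with a double bond to nitrogen. In words, thiophen-2-yl stands in place of 4-methylphenyl on a carbon with a double bond to nitrogen. Within the data shown here, no measured pair shows what this swap does. In this assay, only a small gain in inhibition is expected, and a result beyond the scatter is not assured. Compound 3 could also end up as a limit rather than a number. The expected move is an at least 1.4-fold lower number from compound 1 to compound 3 (0.15 log units; that floor lies within the scatter). For compound 3, the estimate is 45000 nM, with an expected range from 15000 nM to 90000 nM.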

Compound 3, half-maximal inhibitory concentration: > 64000 nM
Compound 3 ended at the assay's limit (the forecaster's own chance of this, stated with the estimate: 50%); at least 1.4-fold (0.15 log units) between middle value and limit.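

In this assay compound 3 ends at a limit and not at a number, just as compound 1 does, so no step from one to the other can be read: the limit of > 64000 nM in this assay, at which 2 of the 3 values shown sit.

The compounds shown leave open whether thiophen-2-yl in place of 4-methylphenyl changes inhibition at all, in either direction.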